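Removing the 4-methoxybenzyl group from a hydroxy-triterpenoid-like acid

A few compounds are considered here, and "the series" means these few. Any claim that something is new, unique, unknown or untested is made for them only; others in the source may bear on it.

Measured compounds:
compound 1 `COc1ccc(CO[C@H]2CC[C@]3(C)C[C@H](Cc4ccc(C(=O)O)cc4)CCC3C2(C)C)cc1`: 200000 nM
compound 2 `COc1ccc(CO[C@H]2CC[C@]3(C)C[C@H](Cc4ccccc4C(=O)O)CCC3C2(C)C)cc1`: 166000 nM
compound 3 `CC1(C)C2CC[C@@H](Cc3ccc(C(=O)O)cc3)C[C@@]2(C)CC[C@@H]1O`: 378000 nM

The three compounds were tested in a functional assay on SK-MEL cells (Homo sapiens) for cytotoxicity; on this read-out lower numbers stand for stronger inhibition and higher numbers for weaker inhibition. Compound 1 gives 200000 nM, compound 2 gives 166000 nM and compound 3 gives 378000 nM in this assay.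

Compounds 1 and 2 share the same atoms joined differently; the difference is 2-carboxyphenyl in place of 4-carboxyphenyl on a saturated chain carbon bound to a saturated ring carbon. This rearrangement gives a 1.2-fold lower number from compound 1 to compound 2 (0.08 log units; within the scatter), so the two values are not distinguishable here.

Compound 3 differs from compound 1 by hydrogen in place of 4-methoxybenzyl on an oxygen on a saturated carbon. The step is a 1.9-fold higher number from compound 1 to compound 3 (0.28 log units; within the scatter), again within the scatter of this assay. Compound 3 and compound 2 are not joined by a directly computed step; their values simply stand apart by more than the scatter.

Compound 4 `CC1(C)C2CC[C@@H](Cc3ccccc3C(=O)O)C[C@@]2(C)CC[C@@H]1O` has not yet been measured. It differs from compound 2 by hydrogen in place of 4-methoxybenzyl on an oxygen on a saturated carbon, the same change as that between compound 1 and compound 3, made on the same place. Because the earlier step was a 1.9-fold higher number from compound 1 to compound 3 (0.28 log units; within the scatter), a step of similar size is expected here, so compound 4 is estimated at a 1.8-fold higher number from compound 2 to compound 4 (0.26 log units; within the scatter) relative to compound 2. For compound 4 the value in this assay is therefore expected to be around 300000 nM, most likely between 150000 nM and 600000 nM.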

Compound 4, half-maximal inhibitory concentration: 484000 nM
Beside the measured number, compound 4's estimate is 1.6-fold (0.21 log units) below it, and the stated range covers the measured number.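

Replacing the 4-methoxybenzyl group on the oxygen with hydrogen gives a 2.9-fold higher number from compound 2 to compound 4 (0.46 log units; beyond the scatter) in this assay, a modest step that lies beyond the scatter. Set beside the earlier case, the change carries from one core to the other with no difference that this read-out can resolve, since both steps run towards a higher number and the gap between them is small: the same change on two cores in this assay, a 1.9-fold higher number (0.28 log units; within the scatter) from compound 1 to compound 3 and a 2.9-fold higher number (0.46 log units; beyond the scatter) from compound 2 to compound 4, 1.5-fold (0.19 log units) apart, within the scatter of two such steps. Among these compounds, only two pairs stand behind this, so it does not show that the core carrying the 2-carboxyphenyl group responds more strongly than the one carrying the 4-carboxyphenyl group, although only its step lies beyond the scatter, and it does not show that the change would behave the same way on any core outside these four compounds.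

The compounds shown leave open how other groups on that oxygen would read, such as a methyl, an acetyl or a benzyl without the methoxy. They also leave open what an amide or a nitrile in place of the carboxylic acid, or a longer chain in place of the single saturated chain carbon, would do to the number in this assay.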